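The compounds below may be only part of what the source reports. "The series", "measured", "known", "first", "only" and "open" are said of these compounds alone.

Measured compounds:
Compound 1 `Cc1nc2ccccc2c(=O)n1/N=C/c1ccc(Oc2ccc3ccccc3c2)cc1` – 5.22
Compound 2 `Cc1cc(Oc2ccc(/C=N/n3c(C)nc4ccccc4c3=O)cc2)ccc1Cl` – 4.41
Compound 3 `Cc1cc(Oc2ccc(/C=N/n3c(-c4ccccc4)nc4ccccc4c3=O)cc2)ccc1Cl` – 6.52

Of the compounds shown here, three sharing one core have been measured in a physicochemical assay for lipophilicity, in phosphate buffer, measured as octanol-water partition; a higher number here means a more lipophilic compound, a lower number a more polar compound. Compound 2 stands lowest, and two single changes lead away from it. The change naphthalen-2-yl in place of 4-chloro-3-methylphenyl on an oxygen on an aromatic ring gives a number 0.81 log units higher from compound 2 to compound 1 (beyond the scatter). The change phenyl in place of methyl on an aromatic carbon gives a number 2.11 log units higher from compound 2 to compound 3 (beyond the scatter), and compound 3 therefore stands highest of the three, with compound 1 nearer to it and compound 2 furthest away.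

Compound 4 `O=c1c2ccccc2nc(-c2ccccc2)n1/N=C/c1ccc(Oc2ccc3ccccc3c2)cc1` has not yet been measured in this assay. It differs from compound 3 by naphthalen-2-yl in place of 4-chloro-3-methylphenyl on an oxygen on an aromatic ring. This is the same change that carries compound 2 to compound 1, and it sits at the same place in both pairs; the two cores on which it is made differ as described by phenyl in place of methyl on an aromatic carbon. Because a number 0.81 log units higher from compound 2 to compound 1 (beyond the scatter) was a modest rise beyond the scatter, the step from compound 3 to compound 4 is expected to be of about the same size, a number 0.78 log units higher from compound 3 to compound 4 (beyond the scatter). This expectation rests on one measured pair only, so its transfer to the core of compound 3 is not secured by a second example.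

Compound 4 is therefore estimated at 7.3 in this assay, with a likely range from 6.8 to 7.8.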

Compound 4, partition coefficient: 6.53
The estimate for compound 4 lay 0.77 log units above the measured number; the measured number lies below the stated range.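

In this assay, the change to naphthalen-2-yl in place of 4-chloro-3-methylphenyl gave a number 0.81 log units higher from compound 2 to compound 1 (beyond the scatter) on the core bearing methyl, but on the core bearing phenyl it gives a number 0.01 log units higher from compound 3 to compound 4 (within the scatter) and leaves compound 3 and compound 4 indistinguishable, so the step seen on one core did not carry over to the other. The companion change, phenyl in place of methyl on an aromatic carbon, likewise differs with its surroundings, giving a number 2.11 log units higher from compound 2 to compound 3 (beyond the scatter) but a number 1.31 log units higher from compound 1 to compound 4 (beyond the scatter) in the series with naphthalen-2-yl, so in these four compounds the two changes do not simply add. This single set of four compounds does not show how the change would behave on any other core, nor does anything measured here say why the two steps differ.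

The compounds shown leave open whether the step would return on a core carrying a longer chain, such as n-butyl, in place of methyl or phenyl on that aromatic carbon. They also leave open how an aryl group bearing an amine or a carboxylic acid would compare on the oxygen on an aromatic ring, on either core.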